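Butyl for Isopropyl on the Aryl Tail

The source may report more compounds than this note shows. Statements on the series, on what has been measured and on what is new or still open speak of the compounds shown alone.

Compound 1 `CCCc1cc(-c2cn([C@H]3C[C@H](OC(C)=O)[C@@H](COC(C)=O)O3)c(=O)[nH]c2=O)on1` and compound 2 `CC(=O)OC[C@H]1O[C@@H](n2cc(-c3cc(-c4ccc(C(C)C)cc4)no3)c(=O)[nH]c2=O)C[C@@H]1OC(C)=O` share one core and differ only in the group carried on an aromatic carbon. In a functional assay on ACHN cells (Homo sapiens) for cytotoxicity, read by sulforhodamine B assay, tested at 10 uM (on this read-out higher numbers stand for more inhibition at the one concentration tested (going by the name of the read-out) and lower numbers for less inhibition), compound 1 gives 99.5% and compound 2 gives 90.1%. Going by the values given here, the one measured step between them, a number 9.4 percentage points lower from compound 1 to compound 2 (within the scatter), lies within the scatter. Compound 2 therefore holds the lower of the two numbers, with compound 1 as its nearest neighbour inside the scatter, so no order between the two can be claimed.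

Compound 3 `CCCCc1ccc(-c2cc(-c3cn([C@H]4C[C@H](OC(C)=O)[C@@H](COC(C)=O)O4)c(=O)[nH]c3=O)on2)cc1` differs from compound 2 in a single place: butyl in place of isopropyl on an aromatic carbon. Among the compounds with values here, no measured step covers this exact exchange. Within the data shown here, the only step that bears on it, a number 9.4 percentage points lower from compound 1 to compound 2 (within the scatter), altered the group at the same aromatic carbon and produced no change beyond the scatter. Since compound 2 already sits high on the scale with 90.1%, little room remains upward. Compound 3 is therefore expected to give 91%, with a range from 76% to 100%. The step this estimate implies, a number 0.9 percentage points higher from compound 2 to compound 3 (within the scatter), is expected to stay within the scatter.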

Compound 3, a percentage reported as inhibition, at one concentration (the size of the read-out at that concentration, not a potency): 80.5%
Compound 3: the middle estimate sits 10.5 percentage points above what was measured, and the stated range covers the measured number.
By their numbers in this assay, from the lowest: compounds 3, 2 and 1 (each within the scatter of the next, the first and the last beyond it).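

Taken alone, butyl in place of isopropyl on the aromatic carbon para to a large group gives a number 9.6 percentage points lower from compound 2 to compound 3 (within the scatter) in this assay and so cannot be told apart from the scatter of repeated measurements. Going by these compounds alone, the wider exchange of 4-butylphenyl in place of propyl gives a number 19 percentage points lower from compound 1 to compound 3 (beyond the scatter) and is the first step at this position to pass beyond that scatter, which shows that the read-out here can respond to the group carried, though only modestly, and that the isopropyl and butyl forms of the aryl tail cannot be ranked against each other. Nothing available here accounts for these numbers.

The compounds shown leave open whether a longer chain such as hexyl on the phenyl ring would take the read-out further from that of compound 1 or leave it within the scatter of compound 3. They also leave open how an unsubstituted phenyl, or an amine or a carboxylic acid at the same aromatic carbon, would read in this assay at the one concentration tested.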